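A few compounds are considered here, and "the series" means these few. Any claim that something is new, unique, unknown or untested is made for them only; others in the source may bear on it.

Compound 1 `COc1ccc(C(=O)/C=C/c2cc(OC)c(OC)cc2OC)c(O)c1`: in an ADME assay on SH-SY5Y cells (Homo sapiens) for cytotoxicity, read by MTT assay, with a stated time of 48 h (on this read-out lower numbers stand for stronger inhibition and higher numbers for weaker inhibition), compound 1 gives only a limit, > 100000 nM.
Compound 2 `COc1ccc(C(=O)/C=C/c2ccc(C(=O)N(C)c3ccccc3)cc2)c(O)c1`: in this assay compound 2 likewise gives only a limit, > 100000 nM.

Neither of these values is a number that can be ranked. For the measured compounds named here, both measured compounds sit at the limit of > 100000 nM in this assay, at which 2 of the 2 values shown sit, so compound 2 stands at the limit of this assay, and the two values show only that neither compound 1 nor compound 2 is cytotoxic within the range that the assay covers.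

Compound 3 `COC(=O)c1ccc(/C=C/C(=O)c2ccc(OC)cc2O)cc1` has not yet been measured. It differs from compound 2 in a single place: methoxy in place of methyl(phenyl)amino on a carbonyl carbon. The methyl(phenyl)amino group leaves and a methoxy enters, on the carbonyl carbon whose other neighbour is an aromatic carbon.

Going by the values given here, no step between measured compounds is available, so there is no measured change to lean on. Because compound 1 and compound 2 both sit at the limit of > 100000 nM in this assay, at which 2 of the 2 values shown sit, compound 3 is expected to stay near the same limit, with no step beyond the scatter in either direction. The expected step of a number no higher from compound 2 to compound 3 (the limit leaves the size open) is thus essentially none. Compound 3 is estimated to give about 100000 nM in this assay, within a range from 40000 nM to 250000 nM.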

Compound 3, half-maximal inhibitory concentration: > 100000 nM
Compound 3 ended at the assay's limit; the forecaster's own chance of this, stated with the estimate: 70%; the middle value lies on the limit itself.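

Compound 3 also gives only a limit in this assay, so no step from compound 2 to compound 3 can be read: the limit of > 100000 nM in this assay, at which 3 of the 3 values shown sit.

The compounds shown leave open whether methoxy in place of methyl(phenyl)amino on a carbonyl carbon changes the cytotoxicity at all, and which compound of this kind would give a readable number.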